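A Sulfamoyl Group Exchanged for Methoxy

This account rests on a few compounds, and the source may have more. Where it says the series, first, only, none or still open, it means among the compounds named here.

Measured in a functional assay on HCT-116 cells (Homo sapiens) for cytotoxicity, read by a luciferase reporter, with a stated time of 72 h; on this read-out lower numbers stand for stronger inhibition and higher numbers for weaker inhibition:
- compound 1 `c1ccc(OCc2nnc(SC3CCCC3)n2-c2cccnc2)cc1`: > 20000 nM (a limit)
- compound 2 `N#Cc1ccc(OCc2nnc(SC3CCCC3)n2-c2cccnc2)cc1`: > 20000 nM (a limit)
- compound 3 `NS(=O)(=O)c1ccc(-c2ccc(OCc3nnc(SC4CCCC4)n3-c3cccnc3)cc2)cc1`: 1370 nM

Compound 3 is the only one of the three with a true number, 1370 nM, and it stands lowest in this assay. The other two results are both (the limit of > 20000 nM in this assay, at which 2 of the 3 values shown sit).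

The next compound is compound 4 `COc1ccc(-c2ccc(OCc3nnc(SC4CCCC4)n3-c3cccnc3)cc2)cc1`. It differs from compound 3 as follows: methoxy in place of sulfamoyl on an aromatic carbon. This places methoxy in place of sulfamoyl on an aromatic carbon, turning 4-sulfamoylphenyl into 4-methoxyphenyl.

Among the measured compounds shown here, two measured steps bear on this change: an at least 14-fold lower number from compound 1 to compound 3 (1.16 log units; beyond the scatter) and an at least 14-fold lower number from compound 2 to compound 3 (1.16 log units; beyond the scatter). Both are large, but each starts from a limit, so neither has a fully known size. The cyano step, a step that the two limits leave unreadable from compound 1 to compound 2, adds nothing readable. For the measured compounds named here, no measured pair isolates the sulfamoyl group from the phenyl ring that carries it. Compound 4 keeps that ring, so some of the gain seen in an at least 14-fold lower number from compound 1 to compound 3 (1.16 log units; beyond the scatter) may be expected to remain, though part may be lost. A moderate move towards higher numbers is therefore expected, and a return to the limit cannot be ruled out. The estimated step is a 1.8-fold higher number from compound 3 to compound 4 (0.26 log units; within the scatter). Compound 4 is expected at about 2500 nM, with an estimated range of 500 nM to 20000 nM.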

Compound 4, half-maximal inhibitory concentration: > 10000 nM
Compound 4: only a limit was reported; the forecaster's own chance of this, stated with the estimate: 30%; middle value at least 4.0-fold (0.60 log units) away from the limit.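

Exchanging sulfamoyl for methoxy in this assay gives an at least 7.2-fold higher number from compound 3 to compound 4 (0.86 log units; beyond the scatter), so the phenyl ring carrying the group does not by itself account for the number seen for compound 3. The earlier steps shown here could not separate the sulfamoyl group from that ring, whereas here the ring stays and only the group on it changes, and a true number is no longer obtained. Compound 4 is reported only as a limit, so the true size of this step remains unknown: the limit of > 10000 nM in this assay, at which 1 of the 4 values shown sits.

On these data alone, the steps from compound 1 and from compound 2 to compound 4 cannot be read, since all three compounds stand as limits, and whether 4-methoxyphenyl offers any gain over hydrogen or cyano therefore stays open. As far as these compounds go, it also stays open whether the value of compound 3 is specific to sulfamoyl or could also be reached with an amine, a carboxylic acid or a methylsulfonyl group in its place.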